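Working notes: phenyl in place of methyl on the ring

The compounds below may be only part of what the source reports. "The series", "measured", "known", "first", "only" and "open" are said of these compounds alone.

Compound 1 `Cc1ccc(S(=O)(=O)NNC(N)=S)cc1` gives 8980 nM in a functional assay on HepG2 cells (Homo sapiens) for inhibition, read by XTT assay, with a stated time of 72 h; a lower number here means a stronger inhibitor, a higher number a weaker inhibitor. Compound 2 `Cc1ccc(S(=O)(=O)NNc2nc(C)cs2)cc1` carries the five-membered aromatic ring with 1 nitrogen and 1 sulfur on the amine nitrogen. In this assay compound 2 reaches only a limit of the assay, < 5650 nM. The step of an at least 1.5-fold lower number from compound 1 to compound 2 (0.20 log units; that floor lies within the scatter) is thus known only as a floor, resting on (the limit of < 5650 nM in this assay, at which 1 of the 2 values shown sits). Compound 3 `Cc1ccc(S(=O)(=O)NNc2nc(-c3ccccc3)cs2)cc1` differs from compound 2 by phenyl in place of methyl on an aromatic carbon. Among the measured compounds shown here, no measured step touches that ring position: the single measured step concerns the group on the amine nitrogen, not the substituent on the ring. Direction and size of the change in this assay are therefore open, and a step within the scatter is as likely as one beyond it. The step expected is a step that the limit leaves unreadable from compound 2 to compound 3. Compound 3 is estimated at 3000 nM, within 700 nM to 13000 nM, with a fair chance that again only a limit is reported.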

Compound 3, half-maximal inhibitory concentration: 9160 nM
Compound 3: middle estimate off by 3.1-fold (0.48 log units), on the low side; the measured number falls inside the stated range.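

Phenyl in place of methyl on this aromatic carbon now has a measured reading in this assay, namely an at least 1.6-fold higher number from compound 2 to compound 3 (0.20 log units; that floor lies within the scatter), and this is the first step at this position. The reading gives no sign that phenyl lowers the number relative to methyl here, yet the floor alone does not carry the step beyond the scatter. The true size of the step stays unread, because compound 2 stands at a limit: the limit of < 5650 nM in this assay, at which 1 of the 3 values shown sits.

An exact number for compound 2 would be needed to tell whether the step exceeds the scatter. From the compounds shown here alone, how an amine or a carboxylic acid on this aromatic carbon, or a longer chain in place of methyl, would read in this assay remains open.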